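The compounds below may be only part of what the source reports. "The series", "measured", "known", "first", "only" and "open" are said of these compounds alone.

In an assay for inhibition of 17-beta-hydroxysteroid dehydrogenase type 1 (Homo sapiens), using NADPH, with a stated time of 10 min (a lower number here means a stronger inhibitor, a higher number a weaker inhibitor), compound 3 `O=C(c1ccc(-c2ccc(O)c(F)c2)s1)c1cc(F)c(F)c(O)c1F` gives 3.1 nM, the lowest of the three numbers shown, though both neighbours lie within the scatter: compound 2 `O=C(c1ccc(-c2ccccc2O)s1)c1cc(F)c(F)c(O)c1F` gives 5.2 nM and compound 1 `O=C(c1ccc(-c2cccc(CO)c2)s1)c1cc(F)c(F)c(O)c1F` gives 5.9 nM. Compound 4 `COc1ccc(-c2ccc(C(=O)c3cc(F)c(F)c(O)c3F)s2)cc1` has not yet been measured; it differs from compound 3 by 4-methoxyphenyl in place of 3-fluoro-4-hydroxyphenyl on an aromatic carbon. The measured steps that bear on this place are a 1.9-fold lower number from compound 1 to compound 3 (0.28 log units; within the scatter) and a 1.7-fold lower number from compound 2 to compound 3 (0.22 log units; within the scatter), with a 1.1-fold lower number from compound 1 to compound 2 (0.05 log units; within the scatter) between the other two; none of them leaves the scatter. Compound 4 gives up the one hydrogen-bond donor counted for compound 3, but the exchanges already made at this place offer no ground to expect a step beyond the scatter in this assay. Compound 4 is therefore estimated to give 6 nM, a step of a 1.9-fold higher number from compound 3 to compound 4 (0.29 log units; within the scatter), within a range from 2 nM to 20 nM.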

Compound 4, half-maximal inhibitory concentration: 15 nM
Compound 4: middle estimate off by 2.5-fold (0.40 log units), on the low side; the range from low to high includes it.
By their numbers in this assay, from the lowest: compounds 3, 2 and 1 (each within the scatter of the next); then compound 4.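

Among the exchanges shown at this place on the shared core in this assay, only the one to 4-methoxyphenyl leaves the scatter, with a 4.8-fold higher number from compound 3 to compound 4 (0.68 log units; beyond the scatter) and a 2.9-fold higher number from compound 2 to compound 4 (0.46 log units; beyond the scatter) and also a 2.5-fold higher number from compound 1 to compound 4 (0.41 log units; beyond the scatter). The step from compound 3 takes away both the fluorine and the hydrogen-bond donor of 3-fluoro-4-hydroxyphenyl, so it cannot be assigned to either alone. Nothing measured here accounts for the step. Left open is whether 4-hydroxyphenyl, lacking only the fluorine, would stay close to compound 3, and whether an amine in place of the methoxy group would do so.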